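Piperazine variants on a shared core at the chemokine receptor

A few compounds are considered here, and "the series" means these few. Any claim that something is new, unique, unknown or untested is made for them only; others in the source may bear on it.

Measured compounds:
Compound 1, `CN(C[C@H]1Cc2c(cccc2N2CCN(C3CC3)CC2)CN1)[C@H]1CCCc2cccnc21`, in a functional assay on CCRF-CEM cells for agonist activity at C-X-C chemokine receptor type 4 (Homo sapiens), read by calcium flux, with a stated time of 25 min; a lower number here means that less compound is needed, a higher number that more compound is needed for the effect: > 30000 nM
Compound 2, `CN(C[C@H]1Cc2c(cccc2N2CCNC(C)(C)C2)CN1)[C@H]1CCCc2cccnc21`, in this assay: > 30000 nM

Compound 1 gives only a limit in this assay, > 30000 nM, not a number. Compound 2 likewise gives only a limit, > 30000 nM. For the measured compounds named here, the one measured step, a step that the two limits leave unreadable from compound 1 to compound 2, cannot be read in size or direction, because of the limit of > 30000 nM in this assay, at which 2 of the 2 values shown sit, and so compound 2 stands at that limit and nowhere more precisely.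

Compound 3, `CC(C)N1CCN(c2cccc3c2C[C@H](CN(C)[C@H]2CCCc4cccnc42)NC3)CC1`, differs from compound 2 in one place: 4-isopropylpiperazin-1-yl in place of 3,3-dimethylpiperazin-1-yl on an aromatic carbon. Going by the values given here, no measured step isolates this exchange. Among the compounds with values here, the only step in hand, from compound 1 to compound 2, is unreadable, so it gives no size to expect; it shows only that two different groups at this position both left the compound at the limit. Within the data shown here, on that basis compound 3 is expected to stay at the limit as well, with a step that the limit leaves unreadable from compound 2 to compound 3 expected to be no step that can be read. The estimate for compound 3 in this assay is 45000 nM, with a range from 10000 nM to 150000 nM.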

Compound 3, half-maximal effective concentration: > 30000 nM
Compound 3 was reported as a limit; the forecaster's own chance of this, stated with the estimate: 85%; the middle value lies beyond the limit too.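

In this assay compound 3 gives only a limit, > 30000 nM, not a number. No new step among compound 1, compound 2 and compound 3 can be read, because all three share one bound: the limit of > 30000 nM in this assay, at which 3 of the 3 values shown sit.

The compounds shown leave open how far apart these three truly lie, and whether any group at this place on the shared core would give a measurable value.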